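Replacing a Methyl Group by Nitro: What to Expect

The source may hold more compounds than are shown below. What is called first, only, known or untested is meant among the compounds shown, and "the series" means these compounds.

Compound 1, `CS(=O)(=O)Nc1ccc(-n2cc(COc3ccccc3Cl)nn2)cc1Oc1ccccc1`, gives 21100 nM in a functional assay on DU-145 cells (Homo sapiens) for inhibition, read by MTT assay, with a stated time of 48 h; a higher number here means a weaker inhibitor, a lower number a stronger inhibitor.
Compound 2, `Cc1ccc(OCc2cn(-c3ccc(NS(C)(=O)=O)c(Oc4ccccc4)c3)nn2)cc1`, gives 8200 nM.
Compound 3, `CS(=O)(=O)Nc1ccc(-n2cc(COc3ccc(Cl)cc3)nn2)cc1Oc1ccccc1`, gives 6400 nM.

Compound 2 stands second highest of these three numbers. The step of a 1.3-fold lower number from compound 2 to compound 3 (0.11 log units; within the scatter) is within the scatter, whereas a 2.6-fold lower number from compound 1 to compound 2 (0.41 log units; beyond the scatter) and a 3.3-fold lower number from compound 1 to compound 3 (0.52 log units; beyond the scatter) are beyond it; both of those move the chloro from one position on the ring to another rather than changing the group itself.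

Compound 4, `CS(=O)(=O)Nc1ccc(-n2cc(COc3ccc([N+](=O)[O-])cc3)nn2)cc1Oc1ccccc1`, differs from compound 2 by nitro in place of methyl on an aromatic carbon. Going by the values given here, the only measured step that changes the group on that same aromatic carbon, a 1.3-fold lower number from compound 2 to compound 3 (0.11 log units; within the scatter), stayed within the scatter, and no measured compound carries a nitro group. The step of a 1.2-fold lower number from compound 2 to compound 4 (0.07 log units; within the scatter) is therefore expected to be small, with no clear direction. Compound 4 is estimated at 7000 nM, within a range of 2500 nM to 20000 nM.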

Compound 4, half-maximal inhibitory concentration: 7200 nM
The estimate for compound 4 lay 1.0-fold (0.01 log units) below the measured number, and the stated range covers the measured number.
By their numbers in this assay, from the lowest: compounds 3, 4 and 2 (each within the scatter of the next); then compound 1.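

In this assay, nitro reads like methyl and chloro on this ring carbon: a 1.1-fold lower number from compound 2 to compound 4 (0.06 log units; within the scatter) and a 1.1-fold higher number from compound 3 to compound 4 (0.05 log units; within the scatter) both lie within the scatter, so a group with more heavy atoms and with hydrogen-bond acceptors brings no visible shift here. Compound 1, with its 2-chlorophenyl, stays apart from this third group as well, with a 2.9-fold lower number from compound 1 to compound 4 (0.47 log units; beyond the scatter) beyond the scatter. No measurement shown gives a reason for either result. From the compounds shown here alone, whether an amine or a carboxylic acid on this same ring carbon would read alike remains open.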